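A few compounds are considered here, and "the series" means these few. Any claim that something is new, unique, unknown or untested is made for them only; others in the source may bear on it.

Measured in a functional assay on HL-60 cells (Homo sapiens) for cytotoxicity, read by luminescence and CellTiter-Glo, with a stated time of 3 days (on this read-out higher numbers stand for weaker inhibition and lower numbers for stronger inhibition), so far:

- Compound 1 `N#Cc1ccc(NC(=O)c2cc(Cc3ccccc3)ccc2O)cc1` gives 1740 nM
- Compound 2 `O=C(Nc1ccc(C(F)(F)F)cc1)c1cc(Br)ccc1O` gives 580 nM
- Compound 3 `N#Cc1ccc(NC(=O)c2cc(Br)c(-c3ccccc3)cc2O)cc1` gives 700 nM

Compound 3 (700 nM) lies within the usual scatter of compound 2 (580 nM), so these two cannot be told apart. Compound 1 (1740 nM) carries a higher number than compound 3, beyond the scatter, which means weaker inhibition.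

Compound 4 `N#Cc1ccc(NC(=O)c2cc(Br)ccc2O)cc1` has not yet been measured. It is compound 3 with hydrogen in place of phenyl on an aromatic carbon, a carbon ortho to a bromo group and meta to a hydroxy group.

Among the compounds with values here, no two measured compounds differ in one place only, so nothing here shows directly what losing that phenyl does. Within the data shown here, the only guide is the modest spread of values, from compound 2 (580 nM) to compound 1 (1740 nM). In this assay no step beyond the scatter is expected, only a small one (a 1.1-fold higher number from compound 3 to compound 4 (0.06 log units; within the scatter)). The estimate for compound 4 is 800 nM (expected range 300 nM to 2200 nM).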

Compound 4, half-maximal inhibitory concentration: 620 nM
Compound 4: middle estimate off by 1.3-fold (0.11 log units), on the high side, within the range that was stated.
By their numbers in this assay, from the lowest: compounds 2, 4 and 3 (each within the scatter of the next); then compound 1.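

In this assay, the phenyl ortho to a bromo group and meta to a hydroxy group can be replaced by hydrogen without a difference that stands out from the scatter (a 1.1-fold lower number from compound 3 to compound 4 (0.05 log units; within the scatter)), so the phenyl is not needed to reach this level of inhibition. Nitrile and trifluoromethyl on the other ring also cannot be told apart (a 1.1-fold higher number from compound 2 to compound 4 (0.03 log units; within the scatter)). Only bromo in place of benzyl gives a step that can be read, and a modest one (a 2.8-fold lower number from compound 1 to compound 4 (0.45 log units; beyond the scatter)), with compound 4 the stronger inhibitor of that pair.

Nothing measured here explains these steps. From the compounds shown here alone, it remains open whether an amine or a carboxylic acid on the carbon that carried the phenyl would also leave the number within the scatter of compound 4.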